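The source may hold more compounds than are shown below. What is called first, only, known or untested is meant among the compounds shown, and "the series" means these compounds.

Measured in a functional assay on A549 cells (Homo sapiens) for antiproliferative activity, read by sulforhodamine B assay, with a stated time of 48 h; on this read-out lower numbers stand for stronger inhibition and higher numbers for weaker inhibition:
Compound 1 (`COc1cccc(/C=C/C(=O)C(=Cc2ccc(F)cc2)C(=O)/C=C/c2cccc(OC)c2OC)c1OC`) gives 340 nM
Compound 2 (`COc1ccc(C=C(C(=O)/C=C/c2cccc(OC)c2OC)C(=O)/C=C/c2cccc(OC)c2OC)cc1OC`) gives 170 nM
Compound 3 (`COc1cccc(C=C(C(=O)/C=C/c2cccc(OC)c2OC)C(=O)/C=C/c2cccc(OC)c2OC)c1OC`) gives 320 nM

These three compounds differ only in the group on a double-bonded chain carbon bound to a double-bonded chain carbon. Compound 3, at 320 nM in this assay, cannot be separated from either neighbour: the data show a 1.1-fold lower number from compound 1 to compound 3 (0.03 log units; within the scatter) and a 1.9-fold higher number from compound 2 to compound 3 (0.27 log units; within the scatter) as steps within the scatter, and a 2.0-fold lower number from compound 1 to compound 2 (0.30 log units; within the scatter) is likewise within it.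

The next compound to be tested is compound 4 (`COc1cc(C=C(C(=O)/C=C/c2cccc(OC)c2OC)C(=O)/C=C/c2cccc(OC)c2OC)cc(Br)c1O`), which has no value yet. The change is 3-bromo-4-hydroxy-5-methoxyphenyl in place of 2,3-dimethoxyphenyl on a double-bonded chain carbon bound to a double-bonded chain carbon and replaces 2,3-dimethoxyphenyl with 3-bromo-4-hydroxy-5-methoxyphenyl at that same place. All three measured steps bear on it, since each swaps the group at this place, and none moved the number beyond the scatter. None of compounds 1, 2 or 3 carries a bromine or a hydroxy group there, however, so the expectation is an extrapolation and its range must stay wide. In this assay, no step beyond the scatter is expected, and no firm direction can be given. The estimated step is a 1.3-fold lower number from compound 3 to compound 4 (0.11 log units; within the scatter) and is expected to be small. For compound 4 the estimate is 250 nM, with an expected range from 90 nM to 700 nM.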

Compound 4, half-maximal inhibitory concentration: 200 nM
Beside the measured number, compound 4's estimate is 1.3-fold (0.10 log units) above it; the range from low to high includes it.
By their numbers in this assay, from the lowest: compounds 2, 4, 3 and 1 (each within the scatter of the next).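

In this assay the swap to 3-bromo-4-hydroxy-5-methoxyphenyl gives a 1.6-fold lower number from compound 3 to compound 4 (0.20 log units; within the scatter) alongside a 1.2-fold higher number from compound 2 to compound 4 (0.07 log units; within the scatter) and a 1.7-fold lower number from compound 1 to compound 4 (0.23 log units; within the scatter) so a bromine and a hydroxy group can sit on this double-bonded chain carbon without a step beyond the scatter from any earlier compound. This group is the only one of the four that carries a hydrogen-bond donor, yet all four compounds remain a single set whose numbers cannot be placed in a firm order, and this position has so far shown no measurable preference among the groups placed there. Nothing available explains why the number holds across these groups.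

Going by these compounds, because compound 4 differs from the others in bromine, hydroxy and methoxy together, the share of each in its number remains open. On these data alone, it also remains open whether an amine or a carboxylic acid on the ring at this place, or a longer chain in place of the ring, would move the number beyond the scatter.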